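The source may hold more compounds than are shown below. What is called first, only, known or untested is meant among the compounds shown, and "the series" means these compounds.

Measured compounds:
Compound 1, `Cc1cc(-c2ccccc2)ncc1C(=O)Nc1ccc2cccnc2c1` — 6.7
Compound 2, `O=C(Nc1ccc2cccnc2c1)c1ccc(-c2cccc(F)c2)nc1` — 8.6
Compound 3, `Cc1nc(-c2ccc(F)cc2)ccc1C(=O)Nc1ccc2scnc2c1` — 7.5

In an in vitro functional assay on 1321-N1 cells for antagonist activity at transient receptor potential cation channel subfamily V member 1 (Homo sapiens), read by FLIPR and calcium flux (a higher number here means a more potent compound, by a factor of ten per unit of this negative logarithm, a lower number a less potent compound), compound 2 gives 8.6, the highest number of the three. Its nearest neighbour is compound 3, which in this assay gives 7.5, a gap that lies beyond the scatter; compound 1, which gives 6.7, lies furthest away, also beyond the scatter. For the measured compounds named here, compound 2 is therefore the most potent of the measured set, and no two of the measured compounds differ in only one place, so no single step between them can be read off.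

Compound 4, `O=C(Nc1ccc2cccnc2c1)c1ccc(-c2ccc(F)cc2)nc1`, has not yet been measured. It differs from compound 2 by 4-fluorophenyl in place of 3-fluorophenyl on an aromatic carbon. Going by the values given here, the measured set offers no pair that isolates this change: compound 3 carries a 4-fluorophenyl but also a different amide partner and an added methyl, so its value cannot be set against compound 2 for this change alone. The expectation for the step from compound 2 to compound 4 is therefore a small one, a number 0.30 log units lower from compound 2 to compound 4 (within the scatter), in either direction and probably not beyond the scatter. Compound 4 is estimated at 8.3, in a range from 7.6 to 9.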

Compound 4, negative logarithm of the antagonist equilibrium constant: 8.2
Compound 4: the middle estimate sits 0.10 log units above what was measured; low and high end bracket the measured number.
By their numbers in this assay, from the lowest: compound 1; then compound 3; then compound 4; then compound 2.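

For the compounds shown here, the exchange of 3-fluorophenyl for 4-fluorophenyl, on an aromatic carbon next to the ring nitrogen, is the first change in this set that can be read alone, and in this assay it gives a number 0.40 log units lower from compound 2 to compound 4 (beyond the scatter). The two groups have the same atoms and differ only in where the fluorine sits on the phenyl ring, so this placement has a modest but readable effect on the number, while compound 4 still reaches 8.2 in this series. No measurement here accounts for the size or direction of this step.

The compounds shown leave open whether the same step would appear with another amide partner or with an added methyl on the core, since compound 1 and compound 3 differ from compound 4 in more than one place. They also leave open how a chlorine, a methoxy group or a nitrile would read in place of the fluorine on the phenyl ring at this position.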